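Moving the fluorine: from compound 1 to compound 3

The source may report more compounds than this note shows. Statements on the series, on what has been measured and on what is new or still open speak of the compounds shown alone.

Measured so far in an ADME assay on HepG2 cells (Homo sapiens) for cytotoxicity, read by resazurin assay, with a stated time of 48 h; a higher number here means that more compound is needed for the effect, a lower number that less compound is needed:
- compound 1 `O=C(Nc1ccc(F)c(-c2nc3ncc(-c4ccc(F)cc4)cc3[nH]2)c1)N1CCCC1`: > 50000 nM, a limit
- compound 2 `Cc1nc(C)c(C(=O)Nc2ccc(F)c(-c3nc4ncc(-c5ccccc5Cl)cn4n3)c2)o1`: > 50000 nM, a limit

Compound 1 has no number of its own in this assay, only the limit > 50000 nM. The same holds across the small set, as the limit of > 50000 nM in this assay, at which 2 of the 2 values shown sit. Compound 2 has a different structure, and its reading is also a limit.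

The next compound is compound 3 `O=C(Nc1ccc(F)c(-c2nc3ncc(-c4cccc(F)c4)cc3[nH]2)c1)N1CCCC1`, which has the same atoms as compound 1, joined differently. It carries 3-fluorophenyl in place of 4-fluorophenyl on an aromatic carbon, two atoms from the ring nitrogen: 3-fluorophenyl in place of 4-fluorophenyl on an aromatic carbon.

Within the data shown here, no measured pair shows what a change of this kind does, so the expectation rests only on the two limits. Compound 1 provides the starting point with its limit of > 50000 nM. No step beyond the scatter is expected in this assay, and no direction is favoured. The expected change is a number no higher from compound 1 to compound 3 (the limit leaves the size open). For compound 3 the estimated value is 50000 nM, with an expected range of 25000 nM to 100000 nM, and a report as a limit only is the likeliest outcome.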

Compound 3, half-maximal effective concentration: 28200 nM
Compound 3: middle estimate off by 1.8-fold (0.25 log units), on the high side; the range from low to high includes it.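

In this assay, among these compounds, compound 3 gives 28200 nM, the first reading in this set that is a number and not a limit. Placing 3-fluorophenyl in place of 4-fluorophenyl on this aromatic carbon gives an at least 1.7-fold lower number from compound 1 to compound 3 (0.24 log units; that floor lies within the scatter), and only this floor can be read, with no firm size for the step. The new information is that a change in the place of one fluorine on this phenyl ring, with the atoms of the molecule unchanged, is enough to give a measurable reading at this position, while most of the small set still stands at the limit: the limit of > 50000 nM in this assay, at which 2 of the 3 values shown sit.

On these data alone, the true distance between compound 1 and compound 3 stays open, as does whether the reading of compound 3 reflects something particular to 3-fluorophenyl or would carry over to other groups at this position. Among the compounds shown here, how an amine or a carboxylic acid on this phenyl ring in place of the fluorine would read in this assay is also unresolved, and the single step here supports no trend for the series.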